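Hydroxy to Amino Exchange in Three Measured Compounds

A few compounds are considered here, and "the series" means these few. Any claim that something is new, unique, unknown or untested is made for them only; others in the source may bear on it.

In a functional assay on MCF7 cells (Homo sapiens) for inhibition, read by MTT assay, with a stated time of 2 days (on this read-out lower numbers stand for stronger inhibition and higher numbers for weaker inhibition), the measured compounds are:
compound 1 `COc1cccc(/C=C/c2ccccc2O)c1` with 18 ug/mL,
compound 2 `COc1cccc(/C=C/c2cccc(O)c2)c1` with 13 ug/mL,
compound 3 `COc1cccc(/C=C/c2ccccc2N)c1` with 6.1 ug/mL.

Compound 1 and compound 2 are built from the same atoms joined differently; the difference between the two cores is not broken down here, and their values in this assay lie within the scatter of each other. Compound 3 differs from compound 1 by one change, (amino in place of hydroxy on an aromatic carbon), and the step of a 3.0-fold lower number from compound 1 to compound 3 (0.47 log units; beyond the scatter).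

Compound 4 `COc1cccc(/C=C/c2cccc(N)c2)c1` has not yet been measured in this assay. It differs from compound 2 by amino in place of hydroxy on an aromatic carbon. This is the same kind of change as that from compound 1 to compound 3, but the place is not identical: in compound 3 the amino sits ortho to a large group, whereas in compound 4 it sits meta to a large group. Resting on the single measured step from compound 1 to compound 3, the step from compound 2 to compound 4 is expected to be a 2.6-fold lower number from compound 2 to compound 4 (0.41 log units; beyond the scatter), so compound 4 is estimated at 5 ug/mL, within 2.5 ug/mL to 10 ug/mL.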

Compound 4, half-maximal inhibitory concentration: 34 ug/mL
Compound 4: the middle estimate sits 6.8-fold (0.83 log units) below what was measured; measured number outside the range, above it.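

In this assay, amino in place of hydroxy on the core of compound 2 gives a 2.6-fold higher number from compound 2 to compound 4 (0.42 log units; beyond the scatter), and this step runs against the one seen on the core of compound 1: the same change on two cores in this assay, a 3.0-fold lower number (0.47 log units; beyond the scatter) from compound 1 to compound 3 and a 2.6-fold higher number (0.42 log units; beyond the scatter) from compound 2 to compound 4, 7.7-fold (0.89 log units) apart, beyond the scatter of two such steps

In this series, then, the exchange does not carry over from one core to the other as a fixed step, and even its direction depends on the core that bears it. What lies behind the gap is not shown, and two steps on two closely related cores give no rule for any further core.

The compounds shown leave open how a carboxylic acid or an acetamide would read in place of the hydroxy or amino group on either core. They also leave open whether the two opposite steps would hold on other cell lines, since all four values come from this assay alone.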